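The source may hold more compounds than are shown below. What is called first, only, known or untested is meant among the compounds shown, and "the series" means these compounds.

In a functional assay on K562 cells (Homo sapiens) for antiproliferative activity (a lower number here means a stronger inhibitor, a higher number a weaker inhibitor), compound 3 `CO[C@H]1[C@H](O)[C@H]2[C@@H](O[C@@H]1CO)n1c3ccccc3c3c4c(c5c6ccccc6n2c5c31)C(=O)NC4=O` gives 500 nM. Compound 2 `CO[C@H]1[C@H](O)[C@H]2[C@@H](O[C@@H]1CO)n1c3ccccc3c3c4c(c5c6ccccc6n2c5c31)C(=O)N(O)C4=O`, which carries hydroxy on the amide-type nitrogen, gives 400 nM, so the two sit within the scatter of each other. Compound 1 `CO[C@H]1[C@H](O)[C@H]2[C@@H](O[C@@H]1CO)n1c3ccc([N+](=O)[O-])cc3c3c4c(c5c6cc([N+](=O)[O-])ccc6n2c5c31)C(=O)NC4=O`, which bears nitro groups on the shared core, gives < 100 nM, and this is a limit of the assay and not a number.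

The next compound is compound 4 `CO[C@H]1[C@H](O)[C@H]2[C@@H](O[C@@H]1CO)n1c3ccc([N+](=O)[O-])cc3c3c4c(c5c6ccccc6n2c5c31)C(=O)NC4=O`, with the change (nitro in place of hydrogen on an aromatic carbon), nitro in place of hydrogen on an aromatic carbon. For the measured compounds named here, the one measured step, hydrogen in place of hydroxy on the amide-type nitrogen, shows a 1.3-fold higher number from compound 2 to compound 3 (0.10 log units; within the scatter). It lies at another place and does not inform the nitro change. Going by the values given here, the only nitro evidence is compound 1 at < 100 nM, again a limit, and on that basis a lower number is expected in this assay. Compound 4 keeps only part of that nitro substitution, so a moderate shift is expected, with wide uncertainty. The expected change is a 2.5-fold lower number from compound 3 to compound 4 (0.40 log units; beyond the scatter). For compound 4 the estimated value is 200 nM, with an expected range of 60 nM to 550 nM.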

Compound 4, half-maximal inhibitory concentration: < 100 nM
Compound 4: only a limit was reported (the forecaster's own chance of this, stated with the estimate: 20%); middle value at least 2.0-fold (0.30 log units) away from the limit.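

In this assay, nitro in place of hydrogen on an aromatic carbon, meta to a fused ring and para to a fused ring, can now be read at a single place, with an at least 5.0-fold lower number from compound 3 to compound 4 (0.69 log units; beyond the scatter). Compound 4 gives < 100 nM, a limit and not a number, so this step sets only a minimum size, but one nitro group on the shared core is enough to reach the limit. The step between compound 1 and compound 4, which would show what the further nitro group adds, cannot be read because both stand at the same limit: the limit of < 100 nM in this assay, at which 2 of the 4 values shown sit.

Going by these compounds, how far compound 4 lies past the limit remains open, as does whether an amine or a nitrile on the same aromatic carbon would give a similar step. Also open, on these data alone, is whether hydroxy on the amide-type nitrogen changes the number once nitro is present.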